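The source may hold more compounds than are shown below. What is called first, only, known or untested is meant among the compounds shown, and "the series" means these compounds.

Two compounds built on a shared core have been examined for toxicity. Compound 1 `Cn1c(-c2ccc(Cl)cc2)cnc1NC(=O)c1ccc(F)cc1` gives in a toxicity assay on THP-1 cells (Homo sapiens) for inhibition (on this read-out lower numbers stand for higher toxicity in this test and higher numbers for lower toxicity in this test), a value of 37000 nM. Compound 2 `Cn1c(-c2ccc(Cl)cc2)cnc1NC(=O)c1ncc[nH]1` gives in this assay a value of 52000 nM. Within the data shown here, the only measured step between them, a 1.4-fold higher number from compound 1 to compound 2 (0.15 log units; within the scatter), exchanges the group on the carbonyl carbon and leaves the two numbers indistinguishable, so compound 1 holds the smaller of the two figures without standing apart from compound 2.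

Compound 3 `COc1ccccc1-c1cnc(NC(=O)c2ccc(F)cc2)n1C` has not yet been measured. It departs from compound 1 at a different site: 2-methoxyphenyl in place of 4-chlorophenyl on an aromatic carbon. Among the measured compounds shown here, no measured step touches that aromatic carbon; the single step known so far concerns the carbonyl substituent and was itself within the scatter. The data therefore offer no ground for a shift in either direction, and the expectation in this assay is a step no larger than the scatter. Compound 3 is accordingly estimated at 37000 nM, within 15000 nM to 90000 nM, which corresponds to an expected step of no change at the digits printed from compound 1 to compound 3 (within the scatter).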

Compound 3, half-maximal cytotoxic concentration: > 100000 nM
Compound 3 was reported as a limit; the forecaster's own chance of this, stated with the estimate: 15%; middle value at least 2.7-fold (0.43 log units) away from the limit.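

In this assay, the aromatic carbon that carries the aryl group proves to be a place where a change registers: the exchange of 4-chlorophenyl for 2-methoxyphenyl gives an at least 2.7-fold higher number from compound 1 to compound 3 (0.43 log units; beyond the scatter), in the direction of lower toxicity in this test, whereas the carbonyl exchange gave a 1.4-fold higher number from compound 1 to compound 2 (0.15 log units; within the scatter). For compound 3, the reading of > 100000 nM is a limit of the assay and not a number. The step is therefore known only from one side, and its full size cannot be stated, because compound 3 stands at that limit: the limit of > 100000 nM in this assay, at which 1 of the 3 values shown sits.

The exchange alters two things at once, so the compounds shown do not separate the loss of the chlorine from the arrival of the methoxy group, or the kind of substituent on the phenyl ring from its place there. Going by these compounds, it remains open how 2-chlorophenyl, 4-methoxyphenyl, unsubstituted phenyl or a phenyl ring bearing an amine would read at this carbon, and whether 2-methoxyphenyl would have the same effect alongside the 1H-imidazol-2-yl group on the carbonyl carbon.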